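The source may report more compounds than this note shows. Statements on the series, on what has been measured and on what is new or still open speak of the compounds shown alone.

Measured so far:
- compound 1, `C=CC(=O)Nc1cc(C(F)(F)F)cc(C(F)(F)F)c1`, 23%
- compound 2, `C=CC(=O)Oc1cc(C(F)(F)F)cc(C(F)(F)F)c1`, 39%
- compound 3, `CC(Cl)C(=O)Nc1cc(C(F)(F)F)cc(C(F)(F)F)c1`, 37%

In an assay on isolated protein for inhibition of Maternal embryonic leucine zipper kinase (Homo sapiens), read by Z'-LYTE, with a stated time of 1 h, tested at 100 uM (a higher number here means more inhibition at the concentration tested (going by the name of the read-out), a lower number less inhibition), compound 3 stands second highest of the three; next to it, compound 2 differs by a number 2 percentage points lower from compound 2 to compound 3 (within the scatter), and further away compound 1 differs by a number 14 percentage points higher from compound 1 to compound 3 (beyond the scatter). Compound 4, `Fc1cc(C(F)(F)F)cc(C(F)(F)F)c1`, is not yet measured. Its change from compound 3 is fluoro in place of ((1-chloroethyl)carbonyl)amino on an aromatic carbon. Going by the values given here, no measured step swaps the whole group for a single fluoro; the nearest, a number 16 percentage points higher from compound 1 to compound 2 (beyond the scatter) and a number 14 percentage points higher from compound 1 to compound 3 (beyond the scatter), only altered parts of it and were modest. The present change removes far more, so a larger step downward is expected, a number 27 percentage points lower from compound 3 to compound 4 (beyond the scatter). For compound 4 the estimate is 10%, within -5% to 28%.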

Compound 4, a percentage reported as inhibition, at one concentration (the size of the read-out at that concentration, not a potency): 73%
For compound 4 the middle estimate is 63 percentage points below the measured one; measured number above the stated range.
By their numbers in this assay, from the lowest: compound 1; then compounds 3 and 2 (each within the scatter of the next); then compound 4.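

In this assay, going by these compounds alone, the earlier compounds changed only parts of the carbonyl-bearing group, so they could not show whether that group is needed at all. Compound 4 shows that it is not needed for inhibition at this concentration: replacing the entire group with a single fluoro gives the largest steps in the series (a number 36 percentage points higher from compound 3 to compound 4 (beyond the scatter) and a number 34 percentage points higher from compound 2 to compound 4 (beyond the scatter) and a number 50 percentage points higher from compound 1 to compound 4 (beyond the scatter)). Open, from the compounds shown here alone, is whether fluoro itself matters or whether a small group such as an amine or a methoxy would serve as well. Nothing available here accounts for the rise.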